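The source may report more compounds than this note shows. Statements on the series, on what has been measured and on what is new or still open speak of the compounds shown alone.

In a functional assay on DU-145 cells (Homo sapiens) for cytotoxicity, read by MTT assay, with a stated time of 48 h (on this read-out higher numbers stand for weaker inhibition and lower numbers for stronger inhibition), three compounds have been read. Compound 1 (`COc1ccc(/C=C/C(=O)/C=C/c2cc3ccccc3nc2Oc2ccccc2)cc1OC`) gives > 10000 nM, which is a limit of the assay and not a number. Compound 3 (`COc1ccc(/C=C/C(=O)/C=C/c2cc3ccccc3nc2Oc2ccc(Br)cc2)c(OC)c1`) gives > 10000 nM, which is also a limit. For the measured compounds named here, compound 2 (`COc1cc(OC)c(OC)cc1/C=C/C(=O)/C=C/c1cc2ccccc2nc1Oc1ccccc1`) gives 9220 nM, the only true number among the three. The set therefore sits close to the limit of > 10000 nM in this assay, at which 2 of the 3 values shown sit.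

Compound 4 (`COc1cc(OC)c(OC)cc1/C=C/C(=O)/C=C/c1cc2ccccc2nc1Oc1cccc(Cl)c1`) keeps the rest of compound 2 and turns its phenoxy group into 3-chlorophenoxy, with chloro in place of hydrogen on an aromatic carbon, meta to a large group: chloro in place of hydrogen on an aromatic carbon. Going by the values given here, the only measured step is an at least 1.0-fold lower number from compound 1 to compound 2 (0.03 log units; that floor lies within the scatter). It is a different change, methoxy in place of hydrogen, and its floor lies within the scatter. Among the compounds with values here, no measured step isolates a change on the phenoxy group, so the data give no direction for this one.

No shift beyond the scatter is therefore expected in this assay, and a reading reported only as a limit would be quite possible. The estimated step is a 1.0-fold lower number from compound 2 to compound 4 (0.01 log units; within the scatter), with neither direction favoured. For compound 4 the expected value is 9000 nM, with an estimated range from 4000 nM to 20000 nM.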

Compound 4, half-maximal inhibitory concentration: > 10000 nM
Compound 4: a limit, no number; the forecaster's own chance of this, stated with the estimate: 50%; at least 1.1-fold (0.04 log units) between middle value and limit.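

In this assay, 3-chlorophenoxy in place of phenoxy gives an at least 1.0-fold higher number from compound 2 to compound 4 (0.03 log units; that floor lies within the scatter). For the compounds shown here, this is the first measured step on the phenoxy group, and as compound 4 reads only as a limit, the step is bounded on one side: chloro on this aromatic carbon, meta to a large group, gives no sign of a lower number, while the true size of any rise stays hidden. The reading also adds compound 4 to the compounds that give no true number, so the set sits even more fully at the edge of what the assay can read: the limit of > 10000 nM in this assay, at which 3 of the 4 values shown sit.

The compounds shown leave open how far past the limit compound 4 lies, and so whether chloro on the phenoxy group changes the reading by more than the usual scatter at all. They also leave open whether a different group on that same aromatic carbon, such as an amine, a carboxylic acid or a longer chain, would bring the reading to a true number within the range of the assay.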